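Halogen exchange on the benzylic aryl of compound 1

This account rests on a few compounds, and the source may have more. Where it says the series, first, only, none or still open, it means among the compounds named here.

Within the data shown here, compound 1 `CCc1cc(Nc2nc(N[C@@H](C)c3ccc(F)cc3)nc3ccccc23)n[nH]1` holds the lower of the two numbers measured so far: in an assay on isolated protein for inhibition of G protein-coupled receptor kinase 6 (Homo sapiens), read by scintillation counting, radiometric assay and 33P incorporation, with a stated time of 80 min, in the presence of a further agent that is not named here (on this read-out higher numbers stand for weaker inhibition and lower numbers for stronger inhibition), compound 1 gives 120 nM. Among the measured compounds shown here, its only measured neighbour is compound 2 `CCc1cc(Nc2nc(N[C@@H](C)c3ccc(F)cc3)nc3cc(Cl)ccc23)n[nH]1`, which in this assay gives 440 nM; the step of a 3.7-fold higher number from compound 1 to compound 2 (0.56 log units; beyond the scatter) comes from chloro in place of hydrogen on an aromatic carbon of the shared core. Compound 3 `CCc1cc(Nc2nc(N[C@@H](C)c3ccc(Cl)cc3)nc3ccccc23)n[nH]1` has not been measured. It differs from compound 1 by chloro in place of fluoro on an aromatic carbon. For the measured compounds named here, no measured step touches this position. Going by the values given here, the one step that exists, a 3.7-fold higher number from compound 1 to compound 2 (0.56 log units; beyond the scatter), concerns a chloro added to the core, not a halogen exchanged on the 1-(4-fluorophenyl)ethyl group, so it bears on the question only loosely and gives no direction for it. The expectation for compound 3 is therefore a step of a 1.3-fold higher number from compound 1 to compound 3 (0.10 log units; within the scatter) that stays within the scatter, with a number close to that of compound 1. The estimate for compound 3 in this assay is 150 nM, with a range from 60 nM to 400 nM.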

Compound 3, half-maximal inhibitory concentration: 70 nM
For compound 3 the middle estimate is 2.1-fold (0.33 log units) above the measured one, and the stated range covers the measured number.
By their numbers in this assay, from the lowest: compounds 3 and 1 (each within the scatter of the next); then compound 2.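

Among these compounds, this is the first reading at the halogen on the benzylic aryl: in this assay, the exchange of 4-fluorophenyl for 4-chlorophenyl gives a 1.7-fold lower number from compound 1 to compound 3 (0.23 log units; within the scatter), so compounds 1 and 3 cannot be told apart and this aromatic carbon, para to a large group, accepts either halogen with no resolved effect on the number. The only earlier step, at a different place on the molecule, was a 3.7-fold higher number from compound 1 to compound 2 (0.56 log units; beyond the scatter), so of the two chloro changes shown, only the one on the shared core lies beyond the scatter. Nothing available here accounts for either outcome, and the result of compound 3 carries no explanation with it.

The compounds shown leave open how far this position stays as permissive: only two halogens are represented there, and it remains to be seen whether bromo, methoxy or trifluoromethyl, or a carboxylic acid or an amine on the same aromatic carbon, would stay close to compound 1. Also open, going by these compounds, is whether the exchange of fluoro for chloro reads the same on the chloro-bearing core of compound 2.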